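This account rests on a few compounds, and the source may have more. Where it says the series, first, only, none or still open, it means among the compounds named here.

Measured compounds:
compound 1, `CC(=O)/C(=N\Nc1ccccc1)N(C)c1cccc(Cl)c1`, giving > 10000 nM
compound 2, `CC(=O)/C(=N\Nc1ccccc1)Oc1cccc(Cl)c1`, giving > 10000 nM
compound 3, `CC(=O)/C(=N\Nc1ccccc1C(F)(F)F)N(C)c1cccc(Cl)c1`, giving > 10000 nM

All three have been tested in an assay on isolated protein for binding affinity to corticotropin-releasing factor receptor 1 (Homo sapiens); a higher number here means a weaker inhibitor, a lower number a stronger inhibitor. In this assay compound 1 gives > 10000 nM, which is a limit of the assay and not a number. Compound 2 likewise gives > 10000 nM, again a limit. Compound 3 gives > 10000 nM, once more a limit. How the core of compound 1 and the core of compound 2 differ is not broken down here. Compound 3 arises from compound 1 by trifluoromethyl in place of hydrogen on an aromatic carbon. The resulting step, a step that the two limits leave unreadable from compound 1 to compound 3, has no readable size because of the limit of > 10000 nM in this assay, at which 3 of the 3 values shown sit.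

Compound 4, `CC(=O)/C(=N\Nc1ccccc1C(F)(F)F)Oc1cccc(Cl)c1`, has not yet been measured in this assay. It arises from compound 2 by trifluoromethyl in place of hydrogen on an aromatic carbon, the same change as that from compound 1 to compound 3, made at a place described in the same words. Since that earlier step could not be read, there is no measured size to carry over; what remains is that compound 2 stands at the limit of > 10000 nM in this assay, at which 3 of the 3 values shown sit, so a value near or beyond the limit is the most that can be said. Compound 4 is therefore expected to give 15000 nM in this assay, estimated between 4000 nM and 60000 nM. The step that the limit leaves unreadable from compound 2 to compound 4 is the expected counterpart of the unreadable earlier one, and it is estimated that the assay will again most likely report only a limit.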

Compound 4, inhibition constant: > 10000 nM
Compound 4 gave a limit, no number; the forecaster's own chance of this, stated with the estimate: 85%; the middle value is on the limit's open side.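

Among the compounds shown here, compound 4 gives only a limit in this assay, so neither the step to it from compound 2 nor the one from compound 1 to compound 3 can be read: the limit of > 10000 nM in this assay, at which 4 of the 4 values shown sit. The compounds shown leave open how large the effect of trifluoromethyl in place of hydrogen on an aromatic carbon is, and whether the core of compound 1 and the core of compound 2 differ at all in this assay.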